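Chain length and hexokinase-2 inhibition across four related compounds

A few compounds are considered here, and "the series" means these few. Any claim that something is new, unique, unknown or untested is made for them only; others in the source may bear on it.

Measured compounds:
Compound 1 `O=C(CI)NCCCNc1ncnc2c1ncn2[C@@H]1O[C@H](COP(=O)(O)OP(=O)(O)OP(=O)(O)O)[C@@H](O)[C@H]1O` gives 0% in an assay on isolated protein for inhibition of hexokinase-2 (Rattus norvegicus), with a stated time of 6 h, tested at 10 mM; on this read-out lower numbers stand for less inhibition and higher numbers for more inhibition at the one concentration tested (going by the name of the read-out)
Compound 2 `O=C(CI)NCCNc1ncnc2c1ncn2[C@@H]1O[C@H](COP(=O)(O)OP(=O)(O)OP(=O)(O)O)[C@@H](O)[C@H]1O` gives 0% in this assay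
Compound 3 `O=C(CI)NCCCC(=O)NCCCCCCNc1ncnc2c1ncn2[C@@H]1O[C@H](COP(=O)(O)OP(=O)(O)OP(=O)(O)O)[C@@H](O)[C@H]1O` gives 0% in this assay

All three measured compounds sit at the same point on this read-out. Going by the values given here, the only single-place step among them is no change at the digits printed from compound 1 to compound 2 (within the scatter), a shortening of the chain that left the result unchanged. Compound 3, with its longer chain, stands level with compound 1 and compound 2 within the scatter, so across the whole set no change in chain length has moved the read-out.

Compound 4 `O=C(CI)NCCCCCCCNc1ncnc2c1ncn2[C@@H]1O[C@H](COP(=O)(O)OP(=O)(O)OP(=O)(O)O)[C@@H](O)[C@H]1O` is the next member. It differs from compound 3 by a group of 6 heavy atoms (3 carbon, 1 nitrogen, 1 oxygen, 1 iodine; no ring) in place of a group of 11 heavy atoms (6 carbon, 2 nitrogen, 2 oxygen, 1 iodine; no ring), on a saturated chain carbon, six bonds along the chain from a nitrogen on an aromatic ring. Among the compounds with values here, the step from compound 1 to compound 2, which also alters the chain, showed nothing beyond the scatter, and compound 3 itself is level with both; no measured step bears on this change in any direction. The expected result for compound 4 is therefore a step of no change at the digits printed from compound 3 to compound 4 (within the scatter), none beyond the scatter. Compound 4 is estimated at 0%, within 0% to 10%.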

Compound 4, a percentage reported as inhibition, at one concentration (the size of the read-out at that concentration, not a potency): 30%
For compound 4 the middle estimate is 30 percentage points below the measured one; the whole stated range lies below it.
By their numbers in this assay, from the lowest: compounds 1, 2 and 3 (each within the scatter of the next); then compound 4.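

In this assay, going by these compounds alone, this position proves able to move the result, something the earlier compounds did not show: a group of 6 heavy atoms in place of a group of 11 heavy atoms, six bonds along the chain from a nitrogen on an aromatic ring, gives a number 30 percentage points higher from compound 3 to compound 4 (beyond the scatter). The shorter chains also fall short of compound 4, with a number 30 percentage points higher from compound 2 to compound 4 (beyond the scatter) for 5-(((iodomethyl)carbonyl)amino)pentyl in place of ((iodomethyl)carbonyl)amino, and a number 30 percentage points higher from compound 1 to compound 4 (beyond the scatter) for 4-(((iodomethyl)carbonyl)amino)butyl in place of ((iodomethyl)carbonyl)amino, yet compound 3, with its longer chain, goes against any simple rule that more length gives more inhibition. Nothing at hand gives a reason for this rise.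

The compounds shown leave open whether a still longer unbroken carbon chain would raise or lower the read-out. They also leave open how a chain carrying an amine or a carboxylic acid would read.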